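Dibromo-hydroxyphenyl in place of fluorophenyl on a urea-hydrazone

The compounds below may be only part of what the source reports. "The series", "measured", "known", "first", "only" and "open" are said of these compounds alone.

Measured compounds:
compound 1 `CN(C)CCn1cnnc1-c1cc(Oc2ccc(NC(=O)N/N=C/c3cc(C(C)(C)C)cc(C(C)(C)C)c3O)cc2F)ccn1` gives 590 nM
compound 2 `Cn1ncnc1-c1cc(Oc2ccc(NC(=O)N/N=C/c3ccccc3)cc2F)ccn1` gives 52200 nM
compound 3 `CN(C)CCn1cnnc1-c1cc(Oc2ccc(NC(=O)N/N=C/c3ccc(F)cc3)cc2F)ccn1` gives 1980 nM

These three compounds were tested in a functional assay on NCI-H460 cells (Homo sapiens) for cytotoxicity, read by MTT assay, with a stated time of 72 h; a higher number here means a weaker inhibitor, a lower number a stronger inhibitor. Compound 3 stands second highest of the three numbers: compound 1 gives a lower number, beyond the usual scatter, while compound 2 gives a much higher one, also beyond it. Compound 2 differs from compound 3 in more than one place, so its gap cannot be tied to a single change.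

Compound 4 `CN(C)CCn1cnnc1-c1cc(Oc2ccc(NC(=O)N/N=C/c3cc(Br)c(O)c(Br)c3)cc2F)ccn1` differs from compound 3 in one place: 3,5-dibromo-4-hydroxyphenyl in place of 4-fluorophenyl on a carbon with a double bond to nitrogen. Within the data shown here, no pair of measured compounds isolates this exact change. Still, compound 1, which also carries a hydroxyl on that ring, gives 590 nM, a number below that of compound 3, so a move in the same direction is the expectation here. A decrease in the number beyond the scatter, toward the level of compound 1, is expected for the step of a 2.5-fold lower number from compound 3 to compound 4 (0.39 log units; beyond the scatter) in this assay. For compound 4 the expected value in this assay is therefore 800 nM, with a range from 250 nM to 3000 nM.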

Compound 4, half-maximal inhibitory concentration: 3760 nM
Beside the measured number, compound 4's estimate is 4.7-fold (0.67 log units) below it, and the stated range ends below it.
By their numbers in this assay, from the lowest: compound 1; then compounds 3 and 4 (each within the scatter of the next); then compound 2.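

In this assay, placing 3,5-dibromo-4-hydroxyphenyl in place of 4-fluorophenyl on a carbon with a double bond to nitrogen gives a 1.9-fold higher number from compound 3 to compound 4 (0.28 log units; within the scatter), so the two compounds cannot be told apart. This single change isolates the position, and it shows that a larger ring substituent carrying a hydroxyl and two bromines leaves the cytotoxicity reading indistinguishable from that of the fluorinated ring, so a hydroxyl on this ring does not by itself separate a compound from compound 3. Nothing measured here gives a reason for this result.

As far as these compounds go, the hydroxyl and the two bromines enter together, and their separate contributions remain open. Also open, from the compounds shown here alone, is how a phenyl ring carrying an amine or a carboxylic acid would read at this position.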